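The compounds below may be only part of what the source reports. "The series", "measured", "known", "first", "only" and "open" are said of these compounds alone.

Working notes on the series. In an ADME assay on microsomes from liver (Mus musculus) for metabolic stability, read by LC-MS, using NADPH, with a stated time of 10 min, tested at 0.1 uM (on this read-out higher numbers stand for fast clearance and lower numbers for slow clearance), compound 1 `O=C(NCCCCc1ccccc1)c1cccc(C2SCC(=O)N2c2cccc(-c3c[nH]nn3)c2)c1` gives 951 mL.min-1.g-1. In this assay compound 2 `COc1ccccc1N1C(=O)C(C)SC1c1cccc(C(=O)NCCCCc2ccccc2)c1` gives 2950 mL.min-1.g-1, and compound 3 `COc1ccc(F)cc1N1C(=O)CSC1c1cccc(C(=O)NCCCCn2cccn2)c1` gives 1310 mL.min-1.g-1. Compound 1 sits at the low end of these three numbers: its gap to compound 3 falls within the usual scatter, while its gap to compound 2 lies beyond it. Compound 4 `C#Cc1cccc(N2C(=O)CSC2c2cccc(C(=O)NCCCCc3ccccc3)c2)c1` differs from compound 1 by ethynyl in place of 1H-1,2,3-triazol-4-yl on an aromatic carbon. Among the compounds with values here, no measured pair shows this change on its own. A step toward faster clearance seems likely, because compound 2 gives 2950 mL.min-1.g-1 without a 1H-1,2,3-triazol-4-yl group. For compound 4 in this assay the estimate is 1800 mL.min-1.g-1, with a range from 900 mL.min-1.g-1 to 3600 mL.min-1.g-1, an expected step of a 1.9-fold higher number from compound 1 to compound 4 (0.28 log units; within the scatter).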

Compound 4, intrinsic clearance in microsomes: 1900 mL.min-1.g-1
Compound 4: the middle estimate sits 1.1-fold (0.02 log units) below what was measured; measured number inside the range.
By their numbers in this assay, from the lowest: compounds 1, 3, 4 and 2 (each within the scatter of the next, the first and the last beyond it).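

In this assay, ethynyl in place of 1H-1,2,3-triazol-4-yl on an aromatic carbon gives a 2.0-fold higher number from compound 1 to compound 4 (0.30 log units; within the scatter) and so stays within the scatter. Within the data shown here, this is the only pair that differs in one place, and it shows that this position tolerates the loss of the five-membered aromatic ring, with its hydrogen-bond donor and acceptors, without a clear shift in clearance. Nothing available explains this result. On these data alone, whether a nitrile, an amine or a carboxylic acid on this aromatic carbon would move clearance beyond the scatter remains open.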